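The compounds below may be only part of what the source reports. "The series", "measured", "known", "first", "only" and "open" are said of these compounds alone.

Of the compounds shown here, three have been tested in a functional assay on M14 cells (Homo sapiens) for cytotoxicity, read by sulforhodamine B assay, with a stated time of 48 h; a lower number here means a stronger inhibitor of growth, a higher number a weaker inhibitor of growth. Compound 1 `Nc1nc(Cl)c2ncn(Cc3ccccc3CCl)c2n1`, which carries an amino group and a chloro group on its core, gives 39800 nM. Compound 2 `ClCc1ccccc1Cn1cnc2nc(Cl)nc(Cl)c21` gives 3460 nM, and compound 3 `ClCc1ccc(Cn2cnc3c(Cl)nc(Cl)nc32)cc1` gives 24000 nM. Among these three numbers, the one for compound 1 is the largest, but its gap to compound 3 falls within the usual scatter and says nothing on its own, whereas compound 2 lies well beyond the scatter and is clearly the stronger inhibitor of that pair. Among the compounds with values here, no two of the measured compounds differ in only one place, so no single step has been measured directly.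

Compound 4 `ClCc1ccccc1Cn1cnc2c(Cl)nc(Cl)nc21` has not been measured. It differs from compound 1 in one place: chloro in place of amino on an aromatic carbon. Compounds 2 and 3 likewise carry two chloro groups and no amino group on the core; in this assay compound 3 gives a number within the scatter of compound 1, while compound 2 gives a much lower one. On that basis a moderate move toward stronger growth inhibition is expected in this assay, rather than no change. The expected step is a 4.0-fold lower number from compound 1 to compound 4 (0.60 log units; beyond the scatter). For compound 4 the estimated value in this assay is 10000 nM, within a range of 3000 nM to 30000 nM.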

Compound 4, concentration for total growth inhibition: 2810 nM
Estimate against measurement, compound 4: 3.6-fold (0.55 log units) above; the whole stated range lies above it.
By their numbers in this assay, from the lowest: compounds 4 and 2 (each within the scatter of the next); then compounds 3 and 1 (each within the scatter of the next).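

In this assay, replacing amino with chloro on the aromatic carbon between two ring nitrogen atoms gives a 14-fold lower number from compound 1 to compound 4 (1.15 log units; beyond the scatter), a large step beyond the scatter. Within the data shown here, this is the first direct reading of a single change in this set, since the earlier compounds differed from one another in more than one place and could not isolate this position. It shows that growth inhibition in these cells is sensitive to the group on this carbon, at least with the chloromethyl-bearing benzyl group of compound 1 held fixed, but nothing available explains why the step is so large.

Going by these compounds, a single swap cannot separate the effect of adding chloro from the effect of losing amino, so it remains open whether a plain hydrogen, a bromo group, a methoxy group or a dimethylamino group on the same carbon would behave like chloro or like amino. Also open, on these data alone, is whether the same swap would give a step of similar size on a core carrying its benzyl group in a different arrangement.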